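Removing a Methyl Group from an Inactive Amide Series

The compounds below may be only part of what the source reports. "The series", "measured", "known", "first", "only" and "open" are said of these compounds alone.

Three compounds share one core. Compound 1 `C=CC1=C(C(=O)NCc2ccccc2F)C(c2ccc(F)cc2)OC1` carries a 2-fluorobenzyl group on its amide nitrogen. In a functional assay on SW480 cells (Homo sapiens) for cytotoxicity, read by MTT assay, with a stated time of 24 h (on this read-out lower numbers stand for stronger inhibition and higher numbers for weaker inhibition), compound 1 reaches only the limit of the assay, > 100000 nM. Compound 2 `C=CC1=C(C(=O)Nc2ccccc2)C(c2ccc(Cl)c(Cl)c2)OC1` also gives only a limit in this assay, > 100000 nM. Compound 3 `C=CC1=C(C(=O)Nc2ccc(C)cc2)C(c2ccc(F)cc2)OC1`, the starting point here, likewise shows only a limit in this assay, > 100000 nM. Going by the values given here, compound 3 therefore stands nowhere on a scale of numbers: all three values sit at the same limit, (the limit of > 100000 nM in this assay, at which 3 of the 3 values shown sit), and no compound can be set above another. Among the compounds with values here, the one step between measured compounds that differ in one place, a step that the two limits leave unreadable from compound 1 to compound 3, runs from one limit to another and cannot be read. Compound 4 `C=CC1=C(C(=O)Nc2ccccc2)C(c2ccc(F)cc2)OC1` differs from compound 3 by hydrogen in place of methyl on an aromatic carbon, in other words hydrogen in place of methyl on an aromatic carbon. Within the data shown here, no measured step bears on the loss of this methyl, as the only recorded step is unreadable. With compound 3 and its companions all at the limit, the step expected in this assay, a step that the limit leaves unreadable from compound 3 to compound 4, is none beyond the scatter. Compound 4 is estimated at 150000 nM in this assay, within 50000 nM to 500000 nM, most likely again only a limit.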

Compound 4, half-maximal inhibitory concentration: > 100000 nM
Compound 4: a limit, no number (the forecaster's own chance of this, stated with the estimate: 90%); the middle value is on the limit's open side.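

In this assay compound 4 also gives only a limit, as do compound 1, compound 2 and compound 3, so no step among these four compounds can be read. The compounds shown leave open whether any change on the shared core can bring a measurable value in this assay at all.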